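From 2-chlorobenzyl to 4-(trifluoromethyl)benzyl

The source may hold more compounds than are shown below. What is called first, only, known or untested is meant among the compounds shown, and "the series" means these compounds.

In a functional assay on Raji cells (Homo sapiens) for antiproliferative activity, read by MTT assay, with a stated time of 72 h (a lower number here means a stronger inhibitor, a higher number a weaker inhibitor), compound 3 (`CN(Cc1nc(C2CCN(Cc3ccccc3Cl)CC2)no1)c1ncc(C(=O)NO)cn1`) gives 48.3 nM and stands in the middle of the three numbers. Compound 1 (`CN(Cc1nc(C2CCN(Cc3ccccc3F)CC2)no1)c1ncc(C(=O)NO)cn1`) gives a higher 98.6 nM as its result, and compound 2 (`CN(Cc1nc(C2CCN(Cc3ccc(F)cc3)CC2)no1)c1ncc(C(=O)NO)cn1`) gives a lower 22 nM as its result. Compound 4 (`CN(Cc1nc(C2CCN(Cc3ccc(C(F)(F)F)cc3)CC2)no1)c1ncc(C(=O)NO)cn1`) carries 4-(trifluoromethyl)phenyl in place of 2-chlorophenyl (4-(trifluoromethyl)phenyl in place of 2-chlorophenyl on a saturated chain carbon bound to an amine nitrogen in a ring) on a saturated chain carbon bound to an amine nitrogen in a ring. Within the data shown here, two measured steps bear on this change, both modest: (a 4.5-fold lower number from compound 1 to compound 2 (0.65 log units; beyond the scatter)) and (a 2.2-fold higher number from compound 2 to compound 3 (0.34 log units; beyond the scatter)). Among the measured compounds shown here, both favour the 4-fluorophenyl of compound 2, but no measured compound carries trifluoromethyl. For compound 4 the expected step is a small one towards a lower number, within the usual scatter (a 1.7-fold lower number from compound 3 to compound 4 (0.24 log units; within the scatter)). Compound 4 is estimated at 28 nM with an expected range of 11 nM to 75 nM in this measurement.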

Compound 4, half-maximal inhibitory concentration: 207 nM
Compound 4: the middle estimate sits 7.4-fold (0.87 log units) below what was measured; measured number outside the range, above it.
By their numbers in this assay, from the lowest: compound 2; then compound 3; then compound 1; then compound 4.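

In (this assay), 4-(trifluoromethyl)phenyl is a poorer group at this position than 2-chlorophenyl (a 4.3-fold higher number from compound 3 to compound 4 (0.63 log units; beyond the scatter)) and also than 2-fluorophenyl (a 2.1-fold higher number from compound 1 to compound 4 (0.32 log units; beyond the scatter)). Trifluoromethyl in place of fluoro on the aromatic carbon (a 9.4-fold higher number from compound 2 to compound 4 (0.97 log units; beyond the scatter)) shows that a group at the 4-position is not favourable in itself, since compound 2 gives the lowest number and compound 4 the highest. No available measurement explains this reversal. On these data alone, whether 4-chlorophenyl or 4-methoxyphenyl would lie nearer compound 2 or compound 4 remains open.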